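The compounds below may be only part of what the source reports. "The series", "measured", "known", "first", "only" and "open" are said of these compounds alone.

Three compounds share a core in which a sulfonyl group links an aromatic ring to a ring nitrogen, and they were tested in a functional assay on DLD-1 cells (Homo sapiens) for antiproliferative activity, read by CellTiter-Glo, with a stated time of 72 h; a higher number here means a weaker inhibitor, a lower number a stronger inhibitor. Compound 1 `Cc1cc(C)c(S(=O)(=O)N2CCC(N3CCC(C)CC3)CC2)c(C)c1` gives 0.03 nM. Compound 3 `CC(=O)Nc1ccc(S(=O)(=O)N2CCC(N3CCC(C)CC3)CC2)c2ccccc12` gives 1100 nM. Compound 2 `CC1CCN(C2CCN(S(=O)(=O)c3cccnc3)CC2)CC1` gives 2400 nM, the highest of the three numbers, so it is the weakest inhibitor of this set; its nearest neighbour is compound 3, and the gap to compound 1 is very large. The change followed here is made only on compound 2, and the unmeasured compound is compound 4 `CC1CCN(C2CCN(S(=O)(=O)c3ccc(Br)c(Cl)c3)CC2)CC1`. The difference between the two structures is 4-bromo-3-chlorophenyl in place of pyridin-3-yl on a sulfonyl sulfur. For the measured compounds named here, no step between measured compounds lies directly beside this one, so the expectation rests on the spread of the three numbers alone. Compound 1, with 0.03 nM, shows that a different group on the sulfonyl sulfur can go with a far lower number in this assay. For compound 4 a clearly lower number than for compound 2 is therefore expected, a step of an 80-fold lower number from compound 2 to compound 4 (1.90 log units; beyond the scatter) well beyond the scatter. The estimate for compound 4 is 30 nM, with a plausible range from 0.5 nM to 800 nM.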

Compound 4, half-maximal inhibitory concentration: 12 nM
Compound 4: middle estimate off by 2.5-fold (0.40 log units), on the high side; the range from low to high includes it.
By their numbers in this assay, from the lowest: compound 1; then compound 4; then compound 3; then compound 2.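

For the compounds shown here, the change from pyridin-3-yl to 4-bromo-3-chlorophenyl on a sulfonyl sulfur gives, in this assay, a 200-fold lower number from compound 2 to compound 4 (2.30 log units; beyond the scatter), the first step in this set that can be read directly, with the rest of the two molecules identical. It shows that the group at this position can, on its own, move the number by far more than the scatter, and that a carbon-only aromatic ring with a bromine and a chlorine goes with a much lower number than the pyridine ring it replaces. Nothing measured here explains why the number falls with this change.

The step changes three things at once, the ring nitrogen leaves while a chlorine and a bromine enter, so plain phenyl, 4-bromophenyl and 3-chlorophenyl would be needed to tell how much each part contributes. It also remains open which features account for the remaining gap between compound 4 at 12 nM and compound 1 at 0.03 nM, which differ only in the group on the sulfonyl sulfur.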